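Capping the phenol: from compound 3 to compound 4

This account rests on a few compounds, and the source may have more. Where it says the series, first, only, none or still open, it means among the compounds named here.

Compound 1 `COc1ccccc1C(=O)/C=C/c1ccc(O)c(O)c1` gives 27 nM in an assay on RBL-1 cells for inhibition of Polyunsaturated fatty acid 5-lipoxygenase (Rattus norvegicus); a higher number here means a weaker inhibitor, a lower number a stronger inhibitor. Compound 2 `Cc1ccc(O)c(C(=O)/C=C/c2ccc(O)c(O)c2)c1` gives 39 nM. Compound 3 `CCOc1ccc(O)c(C(=O)/C=C/c2ccc(O)c(O)c2)c1` gives 5.3 nM.

Compound 3 shows the lowest number of the three, well separated from compound 1 and compound 2. Compound 4 `CCOc1ccc(OC)c(C(=O)/C=C/c2ccc(O)c(O)c2)c1` carries methyl in place of hydrogen on an oxygen on an aromatic ring, so the hydroxy of compound 3 becomes a methoxy. For the measured compounds named here, the only measured step, a 7.4-fold lower number from compound 2 to compound 3 (0.87 log units; beyond the scatter), concerns the ethoxy, not this oxygen, so it does not speak to the change directly. Compound 1, which also carries a methoxy on that oxygen, sits near compound 2 rather than compound 3. A small to modest rise is therefore expected, a 2.3-fold higher number from compound 3 to compound 4 (0.35 log units; beyond the scatter). Compound 4 is estimated at 12 nM, within 4 nM to 40 nM.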

Compound 4, half-maximal inhibitory concentration: 3.8 nM
Compound 4: the middle estimate sits 3.2-fold (0.50 log units) above what was measured; the whole stated range lies above it.
By their numbers in this assay, from the lowest: compounds 4 and 3 (each within the scatter of the next); then compounds 1 and 2 (each within the scatter of the next).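

In this assay the change from hydroxy to methoxy gives a 1.4-fold lower number from compound 3 to compound 4 (0.14 log units; within the scatter) and so, with the ethoxy present, the hydrogen on this oxygen is not needed for a low number. Compound 1 and compound 4 both carry the methoxy, and adding the ethoxy gives a 7.1-fold lower number from compound 1 to compound 4 (0.85 log units; beyond the scatter) so the low number follows the ethoxy rather than the free hydroxy.

Going by these compounds, whether a longer chain on this oxygen, such as propyl, or a carboxylic acid attached through it would keep the number this low remains open. Nothing available explains the result.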